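One step from compound 1 to compound 3

The source may hold more compounds than are shown below. What is called first, only, known or untested is meant among the compounds shown, and "the series" means these compounds.

In a functional assay on J774.1 cells (Mus musculus) for inhibition, read by Griess assay (a higher number here means a weaker inhibitor, a lower number a stronger inhibitor), compound 1 `CCCCCCCCCCS(=O)(=O)NCCCN(CCCNCCCCNCCCN)CCCNS(=O)(=O)CCCCCCCCCC` gives 1100 nM as the lower of the two numbers measured, and compound 2 `CCCCCCCCCCCCCCCCS(=O)(=O)NCCCN(CCCNCCCCNCCCN)CCCNS(=O)(=O)CCCCCCCCCCCCCCCC` gives 15100 nM as the higher. Compound 3 `CCCCCCCCCCS(=O)(=O)NCCCN(CCCNCCCNCCCCNCCCN)CCCNS(=O)(=O)CCCCCCCCCC` is still unmeasured. The change (4-((3-aminopropyl)amino)butyl)amino in place of ((3-aminopropyl)amino)methyl on a saturated chain carbon, three bonds along the chain from an amine nitrogen puts (4-((3-aminopropyl)amino)butyl)amino in place of ((3-aminopropyl)amino)methyl on a saturated chain carbon, three bonds along the chain from an amine nitrogen. Going by the values given here, no measured pair shows this change. The step expected is a 1.1-fold lower number from compound 1 to compound 3 (0.04 log units; within the scatter) and lies within the scatter, with no clear direction in this assay for now. Compound 3 is estimated at 1000 nM with an expected range from 400 nM to 2800 nM in this reading.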

Compound 3, half-maximal inhibitory concentration: 430 nM
Estimate against measurement, compound 3: 2.3-fold (0.37 log units) above; measured number inside the range.
By their numbers in this assay, from the lowest: compound 3; then compound 1; then compound 2.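

In this assay, (4-((3-aminopropyl)amino)butyl)amino in place of ((3-aminopropyl)amino)methyl on a saturated chain carbon, three bonds along the chain from an amine nitrogen, gives a 2.6-fold lower number from compound 1 to compound 3 (0.41 log units; beyond the scatter). This first reading of the position shows that the larger group is tolerated there, with a modest gain beyond the scatter. Nothing available accounts for that gain.

From the compounds shown here alone, whether a still longer polyamine chain at this position would extend the gain remains open. So does whether a guanidine in place of the amine would keep it.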